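From 4-chlorophenyl to phenyl: compound 2 to compound 3

The source may hold more compounds than are shown below. What is called first, only, known or untested is meant among the compounds shown, and "the series" means these compounds.

Measured so far in a functional assay on HeLa cells (Homo sapiens) for antiproliferative activity, with a stated time of 5 days; on this read-out lower numbers stand for stronger inhibition and higher numbers for weaker inhibition:
- compound 1 `O=C1C=CC2(C=C1)OCC(=O)N2c1nc(-c2ccc3ccccc3c2Br)nn1-c1ccccc1` gives 290 nM
- compound 2 `O=C1C=CC2(C=C1)OCC(=O)N2c1nc(-c2ccc3ccccc3c2)nn1-c1ccc(Cl)cc1` gives 720 nM

Compound 2 has the higher number of the two, and its gap to compound 1 lies beyond the scatter. Compound 3 `O=C1C=CC2(C=C1)OCC(=O)N2c1nc(-c2ccc3ccccc3c2)nn1-c1ccccc1` is not yet measured. It differs from compound 2 by hydrogen in place of chloro on an aromatic carbon. Among the compounds with values here, no measured pair shows this change alone, so the data give no step size for it. No step beyond the scatter is expected in this assay here. The expected step is a 1.1-fold lower number from compound 2 to compound 3 (0.04 log units; within the scatter) and stays within the scatter. For compound 3 the estimate is 650 nM with an expected range from 280 nM to 1500 nM on this read-out.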

Compound 3, half-maximal inhibitory concentration: 120 nM
Compound 3: the middle estimate sits 5.4-fold (0.73 log units) above what was measured; the measured number lies below the stated range.
By their numbers in this assay, from the lowest: compound 3; then compound 1; then compound 2.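

In this assay hydrogen in place of chloro on the aromatic carbon para to a large group gives a 6.0-fold lower number from compound 2 to compound 3 (0.78 log units; beyond the scatter) and so shows that the 4-chlorophenyl group is less favourable than phenyl in this series. Hydrogen in place of bromo on an aromatic carbon gives a 2.4-fold lower number from compound 1 to compound 3 (0.38 log units; beyond the scatter) as a second step in the same direction, and compound 3 has the lowest number of the three. No evidence on the cause of either step is available. From the compounds shown here alone, whether fluoro, methoxy or an amine at the chloro position could match hydrogen remains open. Also open, going by these compounds, is whether the two halogen steps would add up in a compound carrying both bromo and chloro.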